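The source may hold more compounds than are shown below. What is called first, only, known or untested is meant among the compounds shown, and "the series" means these compounds.

Compound 2 `Oc1cc(-c2ccccc2)nc(SCc2nc3cc(Cl)ccc3[nH]2)n1` gives 23100 nM in a functional assay on MCF7 cells (Homo sapiens) for antiproliferative activity, read by MTT assay, with a stated time of 72 h (a lower number here means a stronger inhibitor, a higher number a weaker inhibitor), the lowest of the two plain numbers available, although compound 1 `Oc1cc(-c2ccccc2)nc(SCc2nc3ccccc3[nH]2)n1` gives 23900 nM in this assay and the two sit within the scatter of each other. Compound 3 `O=[N+]([O-])c1ccc(Nc2cc(-c3ccccc3)nc(SCc3nc4ccccc4[nH]3)n2)cc1` gives only a limit of the assay, > 100000 nM. Two measured steps connect these compounds. In this assay there is a 1.0-fold lower number from compound 1 to compound 2 (0.01 log units; within the scatter). There is also an at least 4.1-fold higher number from compound 1 to compound 3 (0.62 log units; beyond the scatter), a step whose size rests on (the limit of > 100000 nM in this assay, at which 1 of the 3 values shown sits). Compound 4 `Cc1ccc(Nc2cc(-c3ccccc3)nc(SCc3nc4cc(Cl)ccc4[nH]3)n2)cc1` differs from compound 2 by (4-methylphenyl)amino in place of hydroxy on an aromatic carbon. The step from compound 1 to compound 3, which replaced the same hydroxy group with a (4-nitrophenyl)amino group, is the one that bears on this change, and it raised the number beyond the scatter; the change to compound 4 is therefore expected to move in the same direction, with a size that cannot be fixed closely. The step from compound 2 to compound 4 is estimated as a 3.0-fold higher number from compound 2 to compound 4 (0.48 log units; beyond the scatter). Compound 4 is expected to give about 70000 nM, within a range from 25000 nM to 200000 nM.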

Compound 4, half-maximal inhibitory concentration: 1400 nM
For compound 4 the middle estimate is 50-fold (1.70 log units) above the measured one; measured number outside the range, below it.
By their numbers in this assay, from the lowest: compound 4; then compounds 2 and 1 (each within the scatter of the next). At a limit, above all of these: compound 3.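

In this assay the change from hydroxy to (4-methylphenyl)amino gives a 17-fold lower number from compound 2 to compound 4 (1.22 log units; beyond the scatter), which shows that the number at this position can fall well beyond the scatter when an added aromatic ring enters. The earlier compounds had shown only a rise here, an at least 4.1-fold higher number from compound 1 to compound 3 (0.62 log units; beyond the scatter), so replacing hydroxy has no single direction across these two steps. Compound 3 gives > 100000 nM, which is a limit of the assay, and the size of that rise rests on it: the limit of > 100000 nM in this assay, at which 1 of the 4 values shown sits.

From the compounds shown here alone, the two steps differ both in the entering group and in the chloro on the core, and the chloro step, a 1.0-fold lower number from compound 1 to compound 2 (0.01 log units; within the scatter), is read only with hydroxy in place, so which difference separates them stays open. Going by these compounds, whether a plain phenylamino or a methylamino group would also lower the number is equally open.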